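Working notes: chloro in place of trifluoromethyl

This account rests on a few compounds, and the source may have more. Where it says the series, first, only, none or still open, it means among the compounds named here.

compound 1 `O=C1OC[C@H](Cc2ccccc2)[C@H]1Cc1ccccc1` gives 77000 nM
compound 2 `COCOc1ccccc1C[C@H]1C(=O)OC[C@@H]1Cc1ccccc1` gives 76000 nM
compound 3 `O=C1OC[C@H](Cc2ccccc2)[C@H]1Cc1ccccc1C(F)(F)F` gives 37000 nM

In a functional assay on HL-60 cells (Homo sapiens) for cytotoxicity, read by WST assay, with a stated time of 48 h (on this read-out lower numbers stand for an effect already at smaller amounts and higher numbers for an effect only at larger amounts of compound), compound 3 gives 37000 nM as the lowest of the three numbers. Compound 4 `O=C1OC[C@H](Cc2ccccc2)[C@H]1Cc1ccccc1Cl` carries chloro in place of trifluoromethyl on an aromatic carbon. Going by the values given here, no chloro compound has been measured yet. Among the compounds with values here, two measured steps bear on this change: trifluoromethyl in place of hydrogen gave a 2.1-fold lower number from compound 1 to compound 3 (0.32 log units; beyond the scatter) and methoxymethoxy in place of hydrogen gave a 1.0-fold lower number from compound 1 to compound 2 (0.01 log units; within the scatter) on the same read-out. With steps this small, the step expected in this assay is a 1.2-fold higher number from compound 3 to compound 4 (0.09 log units; within the scatter) and no shift clearly beyond the scatter is anticipated. The estimated value for compound 4 is 45000 nM (expected range 22000 nM to 85000 nM).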

Compound 4, half-maximal effective concentration: 37000 nM
Compound 4: the middle estimate sits 1.2-fold (0.09 log units) above what was measured; the range from low to high includes it.
By their numbers in this assay, from the lowest: compounds 3 and 4 (each within the scatter of the next); then compounds 2 and 1 (each within the scatter of the next).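

In this assay, chloro in place of trifluoromethyl gives no change at the digits printed from compound 3 to compound 4 (within the scatter), so at this place, on an aromatic carbon ortho to a large group, the single chlorine atom and the larger trifluoromethyl group are not told apart. Chloro in place of hydrogen gives a 2.1-fold lower number from compound 1 to compound 4 (0.32 log units; beyond the scatter), and chloro in place of methoxymethoxy gives a 2.1-fold lower number from compound 2 to compound 4 (0.31 log units; beyond the scatter), so trifluoromethyl is no longer the only group here with a modest step. The data on hand offer no explanation for these steps. As far as these compounds go, whether an amine or a carboxylic acid at this place would give a larger step remains open.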